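Sulfone series: fluoro for methyl on the shared core

This account rests on a few compounds, and the source may have more. Where it says the series, first, only, none or still open, it means among the compounds named here.

Measured so far in an assay on isolated protein for displacement of a labelled ligand from metabotropic glutamate receptor 5 (Homo sapiens), with a stated time of 60 min, tested at 1 uM; on this read-out higher numbers stand for more inhibition at the one concentration tested (going by the name of the read-out) and lower numbers for less inhibition:
compound 1 `Cc1ccc2ncc(S(=O)(=O)c3cccc(C#N)c3)c(N3CCC(C)CC3)c2c1` gives 52%
compound 2 `Cc1ccc2ncc(S(=O)(=O)c3ccccc3)c(N3CCC(C)CC3)c2c1` gives 67%

Compound 1 stands at the lower of the two numbers shown. For the measured compounds named here, the single measured step, a number 15 percentage points higher from compound 1 to compound 2 (beyond the scatter), is hydrogen in place of cyano on an aromatic carbon, on the ring that carries the sulfonyl group; it is modest but beyond the scatter.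

Compound 3 `CC1CCN(c2c(S(=O)(=O)c3cccc(C#N)c3)cnc3ccc(F)cc23)CC1` is not yet measured. It differs from compound 1 by fluoro in place of methyl on an aromatic carbon of the shared core. Going by the values given here, none of the measured steps touches this position or this kind of exchange: the one step available concerns the cyano group on the other aryl ring and says nothing about the fused ring. Among the compounds with values here, with no step bearing on the change, no movement beyond the scatter is expected in this assay in either direction, and the value of compound 1 is the anchor.

Compound 3 is therefore estimated at 50%, with a range from 30% to 70%. For compound 3 the expected step is a number 2 percentage points lower from compound 1 to compound 3 (within the scatter).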

Compound 3, a percentage reported as inhibition, at one concentration (the size of the read-out at that concentration, not a potency): 93%
For compound 3 the middle estimate is 43 percentage points below the measured one, and the stated range ends below it.
By their numbers in this assay, from the lowest: compound 1; then compound 2; then compound 3.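

In this assay, the position on the shared core that carries methyl in compound 1 proves to be a sensitive one: fluoro in place of methyl gives a number 41 percentage points higher from compound 1 to compound 3 (beyond the scatter). For the compounds shown here, the earlier pair covered only an exchange on the ring bearing the sulfonyl group, so this is the first reading of any change on the core, and its step is large where the earlier one was modest. With the nitrile kept on the sulfonyl-bearing ring, compound 3 gives 93%, so the nitrile does not rule out a high number in this series, while nothing available here accounts for the size of the step.

On these data alone, it remains open whether the gain from fluoro carries over to the analogue without the nitrile, or whether the two exchanges would simply add on the shared core. Also open, as far as these compounds go, is how this position responds to other groups, such as chloro, methoxy or an amine, and how far the single-concentration numbers in this assay would translate into a difference in potency.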